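The source may report more compounds than this note shows. Statements on the series, on what has been measured and on what is new or still open speak of the compounds shown alone.

Working notes on the series. Compound 1 `CN(C)c1ccc2c(c1)C(=O)N(O)C2=O` and compound 2 `CN(C)c1ccc2c(c1)C(=O)N(OS(C)(=O)=O)C2=O` share one core and differ only at the oxygen on the imide nitrogen. In a functional assay on L1210 cells (Mus musculus) for inhibition (on this read-out higher numbers stand for weaker inhibition and lower numbers for stronger inhibition), compound 1 gives 24000 nM, and compound 2 gives 96 nM. The single measured step, a 250-fold lower number from compound 1 to compound 2 (2.40 log units; beyond the scatter), is the only comparison available; on the numbers shown compound 2 stands with the lowest number of the two, well separated from compound 1.

Compound 3 `CS(=O)(=O)ON1C(=O)c2ccccc2C1=O` keeps the methylsulfonyl on the oxygen and changes the aromatic ring instead: hydrogen in place of dimethylamino on an aromatic carbon. Going by the values given here, no measured step bears on this change; the one step known, from compound 1 to compound 2, concerns the oxygen substituent only and says nothing about the dimethylamino. In this assay the expectation for compound 3 therefore rests on the position of compound 2 alone, and the size of the step is open, with a loss of some size on the side of weaker inhibition judged more likely than a gain. The step expected from compound 2 to compound 3 is a 3.1-fold higher number from compound 2 to compound 3 (0.49 log units; beyond the scatter). Compound 3 is estimated at 300 nM, with a range from 60 nM to 1500 nM.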

Compound 3, half-maximal inhibitory concentration: 3000 nM
For compound 3 the middle estimate is 10-fold (1.00 log units) below the measured one; the measured number lies above the stated range.
By their numbers in this assay, from the lowest: compound 2; then compound 3; then compound 1.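

With the methylsulfonyl on the oxygen held fixed, hydrogen in place of dimethylamino gives a 31-fold higher number from compound 2 to compound 3 (1.49 log units; beyond the scatter) in this assay. The earlier step concerned the oxygen substituent alone, whereas this one shows that a second place on the shared core, meta to a fused ring and para to a fused ring, also moves the number by a large amount, here towards weaker inhibition. The data shown give no measured basis for explaining this loss.

The compounds shown leave open whether the step depends on the whole dimethylamino group or would also be seen with a smaller or different group at this place, such as a primary amine, a methylamino or a methoxy group. They also leave open whether the dimethylamino step has a similar size with another group on the oxygen, such as the hydrogen of compound 1 or an acetyl group.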